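The source may report more compounds than this note shows. Statements on the series, on what has been measured and on what is new or still open speak of the compounds shown alone.

Measured compounds:
Compound 1 `O=C(/C=C\c1cccc(O)c1)N1N=C(c2ccncc2)OC1c1c[nH]c2ccccc12` — in an ADME assay on A549 cells (Homo sapiens) for cytotoxicity, read by MTT assay, with a stated time of 48 h (on this read-out lower numbers stand for stronger inhibition of growth and higher numbers for weaker inhibition of growth), compound 1 gives > 30 ug/mL, which is a limit of the assay rather than a number.
Compound 2 `O=C(/C=C\c1cccc([N+](=O)[O-])c1)N1N=C(c2ccncc2)OC1c1c[nH]c2ccccc12` — in this assay compound 2 gives > 30 ug/mL, again a limit.
Compound 3 `COc1ccc(/C=C\C(=O)N2N=C(c3ccncc3)OC2c2c[nH]c3ccccc23)cc1` — in this assay compound 3 gives > 30 ug/mL, also a limit.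

Compound 3 thus stands at the same limit as the other two members; no number separates any of them, and the limit of > 30 ug/mL in this assay, at which 3 of the 3 values shown sit, covers every value shown. The steps between measured compounds are accordingly unreadable: a step that the two limits leave unreadable from compound 1 to compound 2, a step that the two limits leave unreadable from compound 1 to compound 3 and a step that the two limits leave unreadable from compound 2 to compound 3 each run between two limits, so neither size nor direction can be taken from them.

The unmeasured compound 4 `O=C(/C=C\c1cccc(Cl)c1)N1N=C(c2ccncc2)OC1c1c[nH]c2ccccc12` differs from compound 3 by 3-chlorophenyl in place of 4-methoxyphenyl on a double-bonded chain carbon bound to a double-bonded chain carbon. The measured steps that alter the group on the double-bonded chain carbon are a step that the two limits leave unreadable from compound 1 to compound 3 and a step that the two limits leave unreadable from compound 2 to compound 3; both are unreadable and show only that the hydroxy, nitro and methoxy variants of that ring all sit at the limit. Nothing further constrains the present change. The expected step from compound 3 to compound 4 in this assay is a step that the limit leaves unreadable from compound 3 to compound 4, meaning no step beyond the scatter, with compound 4 most likely reported once more as a limit. Compound 4 is estimated at 40 ug/mL in this assay, with a range from 20 ug/mL to 100 ug/mL.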

Compound 4, concentration for 50% growth inhibition: > 30 ug/mL
Compound 4: a limit, no number; the forecaster's own chance of this, stated with the estimate: 80%; the middle value does not contradict the limit.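

In this assay compound 4 gives > 30 ug/mL, a limit and not a number. No new step can be read among compounds 1, 2, 3 and 4, because all four sit at one limit: the limit of > 30 ug/mL in this assay, at which 4 of the 4 values shown sit.

The compounds shown leave open whether any group on the double-bonded chain carbon changes growth inhibition at all, and what true value any of them has.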